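This account rests on a few compounds, and the source may have more. Where it says the series, first, only, none or still open, it means among the compounds named here.

Of the compounds shown here, three that share one core have been tested in a functional assay on HT-1080 cells (Homo sapiens) for cytotoxicity, read by MTT assay, with a stated time of 72 h; on this read-out lower numbers stand for stronger inhibition and higher numbers for weaker inhibition. Compound 1, `N=C(Nc1cccc(C(F)(F)F)c1)c1cc2c(-c3ccccc3)n[nH]c2cn1`, gives 24600 nM in this assay. Compound 2, `Cn1nc(-c2ccccc2)c2cc(C(=N)Nc3cccc(C(F)(F)F)c3)ncc21`, differs from compound 1 by methyl in place of hydrogen on an aromatic nitrogen. In this assay compound 2 gives 17800 nM; the step of a 1.4-fold lower number from compound 1 to compound 2 (0.14 log units; within the scatter) lies within the scatter, so the two values cannot be told apart with confidence. Compound 3, `CN1CCN(c2ccc(NC(=N)c3cc4c(-c5ccccc5)n[nH]c4cn3)cc2)CC1`, differs from compound 1 in more than one place, and the difference between the two cores is not broken down here. In this assay compound 3 gives 11400 nM, a number whose gap to compound 1 lies beyond the scatter while its gap to compound 2 lies within it.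

Compound 4, `CN1CCN(c2ccc(NC(=N)c3cc4c(-c5ccccc5)nn(C)c4cn3)cc2)CC1`, has not yet been measured. Among the compounds with values here, it differs from compound 3 by methyl in place of hydrogen on an aromatic nitrogen, which is the same change, at the same place, as the one that leads from compound 1 to compound 2. Within the data shown here, since only one earlier example of this change exists, the expectation for compound 4 rests on the single step of a 1.4-fold lower number from compound 1 to compound 2 (0.14 log units; within the scatter), and a step of similar size, a 1.3-fold lower number from compound 3 to compound 4 (0.13 log units; within the scatter), is expected here. Compound 4 is therefore estimated at 8500 nM in this assay, with the range expected to run from 3500 nM to 20000 nM.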

Compound 4, half-maximal inhibitory concentration: 1400 nM
Compound 4: middle estimate off by 6.1-fold (0.78 log units), on the high side, and the stated range ends above it.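

On the core of compound 3, methyl in place of hydrogen on the aromatic nitrogen gives an 8.1-fold lower number from compound 3 to compound 4 (0.91 log units; beyond the scatter) in this assay, a clear change on this read-out, whereas the same change on the core of compound 1 gave a step that could not be told from scatter. The size of this step therefore does not carry over unchanged from one core to the other: the same change on two cores in this assay, a 1.4-fold lower number (0.14 log units; within the scatter) from compound 1 to compound 2 and an 8.1-fold lower number (0.91 log units; beyond the scatter) from compound 3 to compound 4, 5.9-fold (0.77 log units) apart, beyond the scatter of two such steps What this does not show is which difference between the two cores goes with the larger step, since compound 1 and compound 3 differ in more than one place, and two pairs of compounds cannot set a rule for any further core.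

The compounds shown leave open whether an ethyl group or a longer chain on that same aromatic nitrogen would lower the number further than methyl does on the core of compound 3. They also leave open how large the step from hydrogen to methyl would be on a core with an amine or a carboxylic acid on the phenyl group that stands two ring bonds from that nitrogen.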